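This account rests on a few compounds, and the source may have more. Where it says the series, first, only, none or still open, it means among the compounds named here.

Measured compounds:
compound 1 `CNC(=O)c1nc(-c2cc(OC)c(OC)c(OC)c2)n(-c2ccc(OC)cc2)n1`: 56%
compound 2 `CCNC(=O)c1nc(-c2cc(OC)c(OC)c(OC)c2)n(-c2ccc(OC)cc2)n1`: 60%
compound 3 `COc1ccc(-n2nc(C(=O)Nc3ccc(C)cc3)nc2-c2cc(OC)c(OC)c(OC)c2)cc1`: 38%

In a functional assay on the whole organism for inhibition, with Rattus norvegicus as the target, read by paw edema, with stated times of 30 min and 1 h, at a dose of 0.28 mmol/kg by the oral route (on this read-out lower numbers stand for less inhibition and higher numbers for more inhibition at the one dose given (going by the name of the read-out)), compound 3 gives the lowest of the three numbers. Both steps leading to it point the same way: a number 18 percentage points lower from compound 1 to compound 3 (beyond the scatter) and a number 22 percentage points lower from compound 2 to compound 3 (beyond the scatter), each beyond the scatter and each of modest size. Between the two alkyl amides themselves the step is a number 4 percentage points higher from compound 1 to compound 2 (within the scatter), so nothing separates compound 1 from compound 2.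

Compound 4 `COc1ccc(-n2nc(C(=O)Nc3ccc(C(=O)O)cc3)nc2-c2cc(OC)c(OC)c(OC)c2)cc1` keeps the shared core and the amide of compound 3 and changes only the group on the aromatic carbon: carboxy in place of methyl on an aromatic carbon. Among the compounds with values here, no measured step touches this position; the measured steps all concern the amide nitrogen, and they say only that the (4-methylphenyl)carbamoyl compound sits below the alkyl amides. Within the data shown here, the move from 4-methylphenyl to 4-carboxyphenyl therefore has no direct precedent here, and the expected step of a number 2 percentage points higher from compound 3 to compound 4 (within the scatter) is none beyond the scatter. Compound 4 is expected to give about 40%, with a range from 20% to 60%.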

Compound 4, a percentage reported as inhibition, in the whole organism at one dose (the size of the read-out at that dose, not a potency): 50%
The estimate for compound 4 lay 10 percentage points below the measured number; the range from low to high includes it.
By their numbers in this assay, from the lowest: compound 3; then compounds 4, 1 and 2 (each within the scatter of the next).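

On the aromatic carbon para to a large group, the number in this assay responds to the substituent: carboxy in place of methyl gives a number 12 percentage points higher from compound 3 to compound 4 (beyond the scatter). The aryl amide therefore need not sit below the alkyl amides, since the 4-carboxyphenyl compound stays within the scatter of both, with a number 6 percentage points lower from compound 1 to compound 4 (within the scatter) and a number 10 percentage points lower from compound 2 to compound 4 (within the scatter), whereas the 4-methylphenyl compound lay beyond it. No measurement at hand bears on why this change moves the number.

The compounds shown leave open whether an amine, a hydroxy group or a methyl ester at the same place would give a number like that of carboxy or like that of methyl. They also leave open whether a carboxylic acid at the end of a saturated chain on the amide nitrogen, with no aromatic ring, would match the 4-carboxyphenyl group.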